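Adding a chloro to compound 2

The source may hold more compounds than are shown below. What is called first, only, known or untested is meant among the compounds shown, and "the series" means these compounds.

Measured so far:
compound 1 `O=S(=O)(Nc1cc(Cl)cc2cc[nH]c12)c1ccc(Cl)cc1` gives 8.5 ug/mL
compound 2 `O=[N+]([O-])c1ccc(S(=O)(=O)Nc2cccc3cc[nH]c23)cc1` gives 7.2 ug/mL

In a functional assay on MC-38 cells (Mus musculus) for antiproliferative activity, read by colorimetric assay and MTT assay (on this read-out higher numbers stand for weaker inhibition and lower numbers for stronger inhibition), compound 2 and compound 1 lie within the usual scatter of each other, so the two numbers set neither apart. Compound 3 `O=[N+]([O-])c1ccc(S(=O)(=O)Nc2cc(Cl)cc3cc[nH]c23)cc1` is compound 2 with chloro in place of hydrogen on an aromatic carbon of the shared core (chloro in place of hydrogen on an aromatic carbon). Among the measured compounds shown here, no measured pair shows this change alone. The nearest guide is compound 1 (8.5 ug/mL), which also bears a chloro on the core. The expected step (a 1.1-fold lower number from compound 2 to compound 3 (0.04 log units; within the scatter)) therefore stays within the scatter. Compound 3 is expected near 6.5 ug/mL (estimated range 2.5 ug/mL to 16 ug/mL).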

Compound 3, half-maximal inhibitory concentration: 13 ug/mL
Estimate against measurement, compound 3: 2.0-fold (0.30 log units) below; the measured number falls inside the stated range.
By their numbers in this assay, from the lowest: compounds 2, 1 and 3 (each within the scatter of the next).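

In this assay chloro in place of hydrogen on this aromatic carbon of the shared core gives a 1.8-fold higher number from compound 2 to compound 3 (0.26 log units; within the scatter) and so does not set compound 3 apart from compound 2. Nitro in place of chloro on an aromatic carbon gives a 1.5-fold higher number from compound 1 to compound 3 (0.18 log units; within the scatter) and also stays within the scatter, so neither change has a readable effect here. Nothing available here explains these numbers. Going by these compounds, whether an amine or a carboxylic acid on this same carbon would give a step beyond the scatter remains open.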